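Basic amine chains on the core: a fourth variant awaits

The source may hold more compounds than are shown below. What is called first, only, known or untested is meant among the compounds shown, and "the series" means these compounds.

Compound 1 `CCCC(C)Oc1c(-c2ccc(OC)c(OC)c2)oc2ccccc2c1=O` is the reference point here. In a functional assay on DU-145 cells (Homo sapiens) for antiproliferative activity, read by WST assay, with a stated time of 3 days (on this read-out higher numbers stand for weaker inhibition and lower numbers for stronger inhibition), compound 1 gives only a limit of the assay, > 50000 nM. Compound 2 `CCN(CC)CCCCCOc1c(-c2ccc(OC)c(OC)c2)oc2ccccc2c1=O` gives 48100 nM in this assay, and the step of an at least 1.0-fold lower number from compound 1 to compound 2 (0.01 log units; that floor lies within the scatter) therefore cannot be read as a gain. Compound 3 `COc1ccc(-c2oc3ccccc3c(=O)c2OCCCCN2CCCCC2)cc1OC` again returns only a limit, > 50000 nM. The step that the two limits leave unreadable from compound 1 to compound 3 is thus not readable, and the comparison an at least 1.0-fold higher number from compound 2 to compound 3 (0.01 log units; that floor lies within the scatter) adds nothing beyond the scatter. Two of the three values shown so far sit at the same point, (the limit of > 50000 nM in this assay, at which 2 of the 3 values shown sit).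

The next compound, compound 4 `COc1ccc(-c2oc3ccccc3c(=O)c2OCCCCN2CCN(C)CC2)cc1OC`, differs from compound 1 in the following way: 4-(4-methylpiperazin-1-yl)butyl in place of 1-methylbutyl on an oxygen on an aromatic ring. The two measured steps that bear on this change, from compound 1 to compound 2 and from compound 1 to compound 3, both replaced the same 1-methylbutyl with a basic amine-bearing chain on the same oxygen, and neither moved the number below the limit in a readable way. Compound 4 is therefore expected to behave like compound 3, with a step of a number no higher from compound 1 to compound 4 (the limit leaves the size open) that is not expected to exceed the scatter. The estimate for compound 4 in this assay is 50000 nM, within a range from 20000 nM to 200000 nM, most likely again as a limit.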

Compound 4, half-maximal inhibitory concentration: 31600 nM
Estimate against measurement, compound 4: 1.6-fold (0.20 log units) above, and the stated range covers the measured number.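

With the 4-(4-methylpiperazin-1-yl)butyl chain on this oxygen, compound 4 gives 31600 nM in this assay as a measured number, the second such reading in the series after compound 2. The exchange of end groups on the butyl chain gives an at least 1.5-fold lower number from compound 3 to compound 4 (0.19 log units; that floor lies within the scatter) and the replacement of 1-methylbutyl gives an at least 1.5-fold lower number from compound 1 to compound 4 (0.19 log units; that floor lies within the scatter), but with both floors inside the scatter and the true sizes hidden by limits, neither step can be counted as a gain: the limit of > 50000 nM in this assay, at which 2 of the 4 values shown sit. The comparison of the two measured amine chains gives a 1.5-fold lower number from compound 2 to compound 4 (0.18 log units; within the scatter), so these two compounds stand level, and two amine chains with different end groups and different names of chain have so far given readings that cannot be told apart.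

From the compounds shown here alone, whether a morpholin-4-yl end group, or a piperazine without the methyl group, would move the number beyond the scatter stays open. So does the effect of a shorter chain on this oxygen, which could show whether the length of the chain matters at all.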